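The source may report more compounds than this note shows. Statements on the series, on what has been measured and on what is new or still open speak of the compounds shown alone.

Compound 2 `CC(C(=O)NCc1ccc(Br)cc1)c1ccc(NS(C)(=O)=O)c(F)c1` carries a bromo group on its benzyl ring, and in an assay on CHO cells for displacement of a labelled ligand from transient receptor potential cation channel subfamily V member 1 (Rattus norvegicus) (on this read-out lower numbers stand for stronger inhibition and higher numbers for weaker inhibition), compound 2 gives 412 nM. Among the measured compounds shown here, that is the lowest of the two numbers known so far; compound 1 `CC(C)(C)c1ccc(CNC(=O)C(C)(C)c2ccc(NS(C)(=O)=O)c(F)c2)cc1` gives 1070 nM in this assay. Compound 3 `CC(C(=O)NCc1ccc(C2CCCC2)cc1)c1ccc(NS(C)(=O)=O)c(F)c1` is the next step: cyclopentyl in place of bromo on an aromatic carbon. For the measured compounds named here, no measured pair shows this exact change, so no firm step size can be drawn from the data; a modest gain, or no change beyond the usual scatter, seems most likely. Compound 3 is therefore expected to give about 250 nM, within a range of 80 nM to 800 nM, which would mean an estimated step of a 1.6-fold lower number from compound 2 to compound 3 (0.22 log units; within the scatter).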

Compound 3, inhibition constant: 93 nM
Compound 3: middle estimate off by 2.7-fold (0.43 log units), on the high side, and the stated range covers the measured number.
By their numbers in this assay, from the lowest: compound 3; then compound 2; then compound 1.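

In this assay, cyclopentyl in place of bromo on this aromatic carbon gives a 4.4-fold lower number from compound 2 to compound 3 (0.65 log units; beyond the scatter), so this position accepts a ring of five carbons and the number falls clearly. Among the compounds shown here, compound 1 differs from both other compounds in more than one place, so only this pair isolates the change. Nothing measured here gives a reason for the gain.

The compounds shown leave open whether the ring itself matters or only the number of carbons. A straight pentyl chain, a cyclohexyl ring or an amine at this place would help to settle that.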